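Benzylic methyl on an inactive aryloxy carbamate series

A few compounds are considered here, and "the series" means these few. Any claim that something is new, unique, unknown or untested is made for them only; others in the source may bear on it.

Compound 2 `CCC(COc1cccc(Cl)c1)OC(=O)NCc1ccccc1` is the parent for this step. In an assay for inhibition of zeta-carotene desaturase, chloroplastic/chromoplastic (Capsicum annuum), using a Dixon plot, with a stated time of 8 h (a higher number here means a weaker inhibitor, a lower number a stronger inhibitor), compound 2 gives > 100000 nM, which is a limit of the assay and not a number. Compound 1 `CCC(COc1cccc(C(F)(F)F)c1)OC(=O)NCc1ccccc1` gives > 100000 nM in this assay, likewise a limit. Compound 3 `CCC(COc1cccc(OC)c1)OC(=O)NCc1ccccc1` gives > 100000 nM in this assay, again a limit. The three aromatic substituents give no readable order: the steps a step that the two limits leave unreadable from compound 1 to compound 2, a step that the two limits leave unreadable from compound 1 to compound 3 and a step that the two limits leave unreadable from compound 2 to compound 3 are all unreadable because of the limit of > 100000 nM in this assay, at which 3 of the 3 values shown sit.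

Compound 4 `CCC(COc1cccc(Cl)c1)OC(=O)N[C@@H](C)c1ccccc1` differs from compound 2 by methyl in place of hydrogen on a saturated chain carbon bound to an amide-type nitrogen and an aromatic carbon, a methyl in place of hydrogen on a saturated chain carbon bound to an amide-type nitrogen and an aromatic carbon, benzyl to 1-phenylethyl. Within the data shown here, no measured step touches this carbon; the measured steps vary only the aromatic substituent, and every value so far sits at the limit. There is no basis for expecting a readable change, so the expected step is a number no higher from compound 2 to compound 4 (the limit leaves the size open). Compound 4 is expected to give about 100000 nM in this assay, within 30000 nM to 300000 nM, most probably reported once more as a limit.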

Compound 4, half-maximal inhibitory concentration: > 100000 nM
Compound 4: only a limit was reported; the forecaster's own chance of this, stated with the estimate: 80%; the middle value lies on the limit itself.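

Compound 4 gives > 100000 nM in this assay as a limit of the assay, not a number. Among these compounds, no step from compound 2 to compound 4 can be read, because both stand at the same limit: the limit of > 100000 nM in this assay, at which 4 of the 4 values shown sit. The compounds shown leave open whether benzyl to 1-phenylethyl, or any of the aromatic substituents, changes inhibition at all.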